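Dimethylamino in place of methyl on the shared core

The source may report more compounds than this note shows. Statements on the series, on what has been measured and on what is new or still open speak of the compounds shown alone.

Measured compounds:
- compound 1 `Nc1nc(-c2cc(N3C[C@H](O)[C@@H](O)C3)ccc2O)cc(C2CCCC2)n1`, 400 nM
- compound 2 `Nc1nc(-c2cc(N3C[C@H](O)[C@@H](O)C3)ccc2O)cc(C2CCCNC2)n1`, > 10000 nM
- compound 3 `Cc1cc(-c2cc(N3C[C@H](O)[C@@H](O)C3)ccc2O)nc(N)n1`, 400 nM

In a functional assay on HCT-116 cells (Homo sapiens) for cytotoxicity, with a stated time of 48 h (a higher number here means a weaker inhibitor of growth, a lower number a stronger inhibitor of growth), compound 1 gives 400 nM and compound 3 gives 400 nM; the two stand level, no change at the digits printed from compound 1 to compound 3 (within the scatter). Compound 2 reaches only a limit of this assay, > 10000 nM, so the limit of > 10000 nM in this assay, at which 1 of the 3 values shown sits, bounds it. The step of an at least 25-fold higher number from compound 1 to compound 2 (1.39 log units; beyond the scatter) is large, and an at least 25-fold lower number from compound 2 to compound 3 (1.39 log units; beyond the scatter) reverses it.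

Compound 4 `CN(C)c1cc(-c2cc(N3C[C@H](O)[C@@H](O)C3)ccc2O)nc(N)n1` differs from compound 3 by dimethylamino in place of methyl on an aromatic carbon. Going by the values given here, the only steps at this aromatic carbon are those above; the large loss belongs to piperidin-3-yl, while methyl and cyclopentyl are level. Dimethylamino is far nearer methyl in size, so a small step is expected, a 1.5-fold higher number from compound 3 to compound 4 (0.18 log units; within the scatter), likely weaker. Compound 4 is estimated at 600 nM, range 150 nM to 3000 nM.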

Compound 4, concentration for 50% growth inhibition: > 10000 nM
Compound 4: no number, only a limit; the forecaster's own chance of this, stated with the estimate: 15%; middle value at least 16-fold (1.22 log units) from the limit.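

In this assay, this aromatic carbon does not accept every small group: dimethylamino gives an at least 25-fold higher number from compound 3 to compound 4 (1.39 log units; beyond the scatter), and against cyclopentyl it gives an at least 25-fold higher number from compound 1 to compound 4 (1.39 log units; beyond the scatter). The loss is therefore not confined to piperidin-3-yl; across these compounds the two groups carrying nitrogen sit at the limit, while the all-carbon methyl and cyclopentyl stand level. Compound 4 reaches only a limit, shared with compound 2, so the step between them cannot be read: the limit of > 10000 nM in this assay, at which 2 of the 4 values shown sit.

Going by these compounds, whether the nitrogen itself goes with the loss stays open. An isopropyl group, the all-carbon counterpart of dimethylamino, or a methoxy group at this carbon would bear on that.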